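The compounds below may be only part of what the source reports. "The series", "measured", "known", "first", "only" and "open" are said of these compounds alone.

Compound 1 `Cc1ccccc1Nc1nc(Nc2cc(Cl)ccn2)ncc1Cl` gives 39600 nM in a functional assay on Jurkat cells (Homo sapiens) for inhibition, read by CCK-8 assay, with a stated time of 48 h; a lower number here means a stronger inhibitor of growth, a higher number a weaker inhibitor of growth. Compound 2 `Cc1ccccc1Nc1nc(Nc2ccc(N3CCCCC3)cn2)ncc1Cl` gives only a limit of the assay, > 100000 nM. Compound 3 `CN1CCN(c2ccc(Nc3ncc(Cl)c(Nc4ccccc4)n3)nc2)CC1` likewise gives only a limit, > 100000 nM.

Compound 3 thus stands at the ceiling of this assay, with no number of its own, and it shares that position with compound 2 (the limit of > 100000 nM in this assay, at which 2 of the 3 values shown sit). Compound 4 `Cc1cccc(Nc2nc(Nc3ccc(N4CCN(C)CC4)cn3)ncc2Cl)c1` has not yet been measured. It differs from compound 3 in one place: methyl in place of hydrogen on an aromatic carbon. For the measured compounds named here, no measured pair shows what a single added methyl does here, and the two values in hand that could speak to it are both limits. The expected step is therefore none beyond the scatter, a number no higher from compound 3 to compound 4 (the limit leaves the size open). Compound 4 is estimated at 100000 nM, between 30000 nM and 300000 nM.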

Compound 4, concentration for 50% growth inhibition: 15300 nM
Beside the measured number, compound 4's estimate is 6.5-fold (0.82 log units) above it; the whole stated range lies above it.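

Changing phenyl to 3-methylphenyl gives an at least 6.5-fold lower number from compound 3 to compound 4 (0.81 log units; beyond the scatter) in this assay. For the compounds shown here, one added carbon on this ring is thus enough to bring a compound from the ceiling down to a readable number, which the earlier compounds could not show. The true size of the step stays open because compound 3 carries only a limit: the limit of > 100000 nM in this assay, at which 2 of the 4 values shown sit.

As far as these compounds go, whether this effect is specific to methyl remains open. An ethyl group, a methoxy group or an amine at the same place could give a smaller, similar or larger step.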